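Halogen swap on the phenoxy ring: cytotoxicity notes

The compounds below may be only part of what the source reports. "The series", "measured", "known", "first", "only" and "open" are said of these compounds alone.

Compound 1 `O=C1N(CCCCCCOc2ccc(C(F)(F)F)cc2)CCN1c1ccncc1` was run in a functional assay on cells (Homo sapiens) for cytotoxicity; on this read-out lower numbers stand for higher toxicity in this test and higher numbers for lower toxicity in this test; compound 1 gives > 25000 nM, which is a limit of the assay and not a number. Compound 2 `O=C1N(CCCCCCOc2ccc(Cl)cc2)CCN1c1ccncc1` in this assay gives > 25000 nM, again a limit. Compound 3 `O=C1N(CCCCCCOc2ccc(Cl)cc2)CCN1c1cccnc1` in this assay gives > 25000 nM, also a limit. Compound 3 therefore stands where every measured member of the series stands, as the limit of > 25000 nM in this assay, at which 3 of the 3 values shown sit, records. The two measured steps, a step that the two limits leave unreadable from compound 1 to compound 2 and a step that the two limits leave unreadable from compound 2 to compound 3, are both of unreadable size for the same reason, and they show nothing about the direction of any change.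

Compound 4 `O=C1N(CCCCCCOc2ccc(F)cc2)CCN1c1cccnc1` differs from compound 3 by fluoro in place of chloro on an aromatic carbon. The step that bears most closely on it is a step that the two limits leave unreadable from compound 1 to compound 2, which also exchanges one substituent on the same aromatic carbon, and its size could not be read. No step beyond the scatter is therefore expected in this assay. The step that the limit leaves unreadable from compound 3 to compound 4 is the estimated consequence. Compound 4 is expected to give 40000 nM in this assay, with a range from 15000 nM to 120000 nM, and most probably to be reported again only as a limit.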

Compound 4, half-maximal cytotoxic concentration: > 25000 nM
Compound 4 ended at the assay's limit (the forecaster's own chance of this, stated with the estimate: 85%); the middle value lies beyond the limit too.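

The exchange of chloro for fluoro gives no readable step between compound 3 and compound 4, which rest at the same limit: the limit of > 25000 nM in this assay, at which 4 of the 4 values shown sit.

With only limits shown, it remains open whether any exchange among compound 1, compound 2, compound 3 and compound 4 changes toxicity in this test.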